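Aryl Returns to the Triazole: From Compound 3 to Compound 4

This account rests on a few compounds, and the source may have more. Where it says the series, first, only, none or still open, it means among the compounds named here.

Compound 3 `COc1nc2ccc(Br)cc2cc1C(c1ccccc1)n1cc(CO)nn1` gives 3.23% in an ADME assay on SK-OV-3 cells (Homo sapiens) for cytotoxicity, read by sulforhodamine B assay, with a stated time of 48 h, tested at 10 uM (a higher number here means more inhibition at the concentration tested (going by the name of the read-out), a lower number less inhibition), the lowest of the three numbers measured. Compound 1 `CCCCc1cn(C(c2ccccc2)c2cc3cc(Br)ccc3nc2OC)nn1` gives 11.1%, and compound 2 `COc1nc2ccc(Br)cc2cc1C(c1ccccc1)n1cc(-c2ccc(OC(F)(F)F)cc2)nn1` gives 14.8%. The step of a number 7.9 percentage points lower from compound 1 to compound 3 (within the scatter) stays within the scatter, whereas the step of a number 11.6 percentage points lower from compound 2 to compound 3 (beyond the scatter) lies beyond it. Compound 4 `COc1nc2ccc(Br)cc2cc1C(c1ccccc1)n1cc(-c2cccc(F)c2)nn1` differs from compound 3 in that (3-fluorophenyl in place of hydroxymethyl on an aromatic carbon). Among the compounds with values here, this change runs opposite to the one from compound 2 to compound 3, so the step of a number 11.6 percentage points lower from compound 2 to compound 3 (beyond the scatter) is the one that bears on it, and a rise of roughly that size is expected in this assay. Compound 4 is therefore expected to give 13%, within a range from 3% to 25%, an expected step of a number 9.8 percentage points higher from compound 3 to compound 4 (within the scatter).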

Compound 4, a percentage reported as inhibition, at one concentration (the size of the read-out at that concentration, not a potency): 12.7%
For compound 4 the middle estimate is 0.3 percentage points above the measured one; low and high end bracket the measured number.
By their numbers in this assay, from the lowest: compounds 3, 1, 4 and 2 (each within the scatter of the next, the first and the last beyond it).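

With 3-fluorophenyl in place of hydroxymethyl on this aromatic carbon, this assay shows a number 9.5 percentage points higher from compound 3 to compound 4 (within the scatter) and so this change alone does not clear the scatter. Against the other groups at this carbon the steps are a number 2.1 percentage points lower from compound 2 to compound 4 (within the scatter) and a number 1.6 percentage points higher from compound 1 to compound 4 (within the scatter) and so 3-fluorophenyl, 4-(trifluoromethoxy)phenyl and butyl cannot be told apart here. Among the four compounds, only compound 2 stands beyond the scatter from compound 3.

On these data alone, how an amine or a carboxylic acid on this carbon would read remains open. Nothing given here accounts for these numbers.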